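From a Cyanobenzyl to a Naphthyl Group on the Shared Core

The source may report more compounds than this note shows. Statements on the series, on what has been measured and on what is new or still open speak of the compounds shown alone.

Compound 3 `COc1ccc(F)cc1CNCCCNc1ccnc2cc(Cc3ccc(C#N)cc3)ccc12` is one of three compounds on a shared core that differ in the group bound to one aromatic carbon. In an ADME assay on HepG2 cells (Homo sapiens) for cytotoxicity, read by luminescence, CellTiter-Glo and ATP content, with a stated time of 72 h (a lower number here means that less compound is needed, a higher number that more compound is needed for the effect), compound 3 gives 6050 nM, the second highest of the three numbers. Compound 1 `COc1ccc(F)cc1CNCCCNc1ccnc2cc(Oc3ccc(C(C)(C)C)cc3)ccc12` gives 7200 nM, and the step of a 1.2-fold lower number from compound 1 to compound 3 (0.08 log units; within the scatter) lies within the scatter, so the two are not distinguished. Compound 2 `COc1ccc(F)cc1CNCCCNc1ccnc2cc(Cc3ccc(F)cc3Cl)ccc12` gives 2460 nM; the step of a 2.5-fold higher number from compound 2 to compound 3 (0.39 log units; beyond the scatter) is beyond the scatter, as is the step of a 2.9-fold lower number from compound 1 to compound 2 (0.47 log units; beyond the scatter). Compound 4 `COc1ccc(F)cc1CNCCCNc1ccnc2cc(-c3cccc4ccccc34)ccc12` has not yet been measured. It differs from compound 3 in one place: naphthalen-1-yl in place of 4-cyanobenzyl on an aromatic carbon. Among the measured compounds shown here, no measured step exchanges a group of this kind on an aromatic carbon of the core. The two steps that do change the group there, a 2.9-fold lower number from compound 1 to compound 2 (0.47 log units; beyond the scatter) and a 2.5-fold higher number from compound 2 to compound 3 (0.39 log units; beyond the scatter), were modest, and the third, a 1.2-fold lower number from compound 1 to compound 3 (0.08 log units; within the scatter), was within the scatter. Compound 4 is therefore expected to land close to compound 3, with any shift unlikely to stand clearly beyond the scatter. The expected step is a 1.3-fold lower number from compound 3 to compound 4 (0.13 log units; within the scatter). The estimate for compound 4 in this assay is 4500 nM, with a range from 1500 nM to 13000 nM.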

Compound 4, half-maximal effective concentration: 16000 nM
Estimate against measurement, compound 4: 3.6-fold (0.55 log units) below; measured number above the stated range.
By their numbers in this assay, from the lowest: compound 2; then compounds 3 and 1 (each within the scatter of the next); then compound 4.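

In this assay naphthalen-1-yl stands apart from every earlier group at this aromatic carbon, with a 2.6-fold higher number from compound 3 to compound 4 (0.42 log units; beyond the scatter), a 2.2-fold higher number from compound 1 to compound 4 (0.35 log units; beyond the scatter) and a 6.5-fold higher number from compound 2 to compound 4 (0.81 log units; beyond the scatter), so compound 4 has the highest number of the four. The earlier compounds had shown only that 2-chloro-4-fluorobenzyl separates from 4-cyanobenzyl and 4-(tert-butyl)phenoxy, two groups that could not be told apart; this result shows that the number at this position can also rise beyond that pair, and the step from compound 2 is the widest seen here. Nothing in hand explains why this exchange raises the number.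

The compounds shown leave open whether a plain phenyl group on the same carbon would read near compound 4 or near compound 3, and so whether the higher number goes with the second aromatic ring or with the loss of the benzyl carbon. They also leave open how a group carrying an amine or a carboxylic acid would read at this position in this assay.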